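Replacing a difluorophenyl with a thiazolyl on the chain

The compounds below may be only part of what the source reports. "The series", "measured", "known", "first", "only" and "open" are said of these compounds alone.

Compound 2 `N=C(NCCCc1c[nH]cn1)NC(=O)CC(c1ccccc1)c1ccc(F)c(F)c1` reaches 81% in a functional assay on cardiac atrium for agonist activity at histamine H2 receptor (Cavia porcellus) (a lower number here means a smaller maximal response, a higher number a larger maximal response), the smaller of the two numbers recorded, though the gap to compound 1 `N=C(NCCCc1c[nH]cn1)NC(=O)CC(c1ccccc1)c1ccccc1`, which reaches 85%, is within the scatter: a number 4 percentage points lower from compound 1 to compound 2 (within the scatter). Compound 3 `N=C(NCCCc1c[nH]cn1)NC(=O)CC(c1ccccc1)c1nccs1` differs from compound 2 by 1,3-thiazol-2-yl in place of 3,4-difluorophenyl on a saturated chain carbon bound to an aromatic carbon and a saturated chain carbon. For the measured compounds named here, the only measured step also exchanged the group on a saturated chain carbon bound to an aromatic carbon and a saturated chain carbon and stayed within the scatter. Compound 3 is therefore expected to show no step beyond the scatter, about a number 1 percentage points lower from compound 2 to compound 3 (within the scatter). The estimated maximal response of compound 3 is 80%, between 62% and 95%.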

Compound 3, largest response reached (Emax), in percent of the reference or control that the assay uses: 100%
For compound 3 the middle estimate is 20 percentage points below the measured one; the whole stated range lies below it.
By their numbers in this assay, from the lowest: compounds 2 and 1 (each within the scatter of the next); then compound 3.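

In this assay this position turns out not to be indifferent to the group it carries: where 3,4-difluorophenyl left the maximal response within the scatter, 1,3-thiazol-2-yl gives a number 19 percentage points higher from compound 2 to compound 3 (beyond the scatter) and likewise a number 15 percentage points higher from compound 1 to compound 3 (beyond the scatter) on the same carbon. The change that moves the response is thus the one that brings a five-membered aromatic ring with 2 hetero atoms. Nothing measured here accounts for the gain. From the compounds shown here alone, whether the ring nitrogen, the sulfur or the smaller ring carries the step stays open, as does what a pyridin-2-yl or a thiophen-2-yl would do at this place.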